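The source may hold more compounds than are shown below. What is called first, only, known or untested is meant among the compounds shown, and "the series" means these compounds.

Measured compounds in the series:
compound 1 `Clc1ccc(C(/C=C/c2ccccc2)=N\Nc2nncc3ccccc23)cc1` — 2.3 nM
compound 2 `O=S(=O)(Nc1ccccn1)c1ccc(Nc2nncc3ccccc23)cc1` — 38 nM
compound 3 `COc1ccc(NC(=S)NNc2nncc3ccccc23)cc1` — 20 nM

In a functional assay on HT-29 cells (Homo sapiens) for antiproliferative activity, read by sulforhodamine B assay, with a stated time of 72 h (a higher number here means a weaker inhibitor, a lower number a stronger inhibitor), compound 2 gives 38 nM, the highest number of the three. Compound 3 gives 20 nM, a gap within the scatter, so the two cannot be ordered. Compound 1 gives 2.3 nM, a gap beyond the scatter.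

Compound 4 `O=S(=O)(Nc1ncccn1)c1ccc(Nc2nncc3ccccc23)cc1` has not been measured. It differs from compound 2 in one place: pyrimidin-2-yl in place of pyridin-2-yl on a sulfonamide nitrogen. Going by the values given here, no pair of measured compounds shows this change, so no step is known for it. The change is expected to bring no step beyond the scatter, with a 1.1-fold higher number from compound 2 to compound 4 (0.02 log units; within the scatter) as the expected step. Compound 4 is estimated at 40 nM, within a range of 15 nM to 120 nM.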

Compound 4, half-maximal inhibitory concentration: 29 nM
Compound 4: the middle estimate sits 1.4-fold (0.14 log units) above what was measured, within the range that was stated.
By their numbers in this assay, from the lowest: compound 1; then compounds 3, 4 and 2 (each within the scatter of the next).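

With a 1.3-fold lower number from compound 2 to compound 4 (0.12 log units; within the scatter) in this assay the two rings on a sulfonamide nitrogen cannot be ordered. Going by these compounds alone, this is the first one-place comparison, and it shows that pyrimidin-2-yl in place of pyridin-2-yl, a swap of one ring carbon for nitrogen, brings no step beyond the scatter at this position. No available data bear on this result.

The compounds shown leave open whether thiazol-2-yl or a plain methyl on that nitrogen would keep the number in this range. As far as these compounds go, removing the ring altogether, leaving the unsubstituted sulfonamide, also remains untested here.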